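The source may report more compounds than this note shows. Statements on the series, on what has been measured and on what is new or still open speak of the compounds shown alone.

Within the data shown here, compound 2 `CCCCNc1ccnc(N)n1` carries a butylamino group and an amino group on its core, and it stands as the higher of the two numbers measured so far in an assay on HEK293 cells for agonist activity at Toll-like receptor 8 (Homo sapiens), read by reporter gene assay (a higher number here means that more compound is needed for the effect, a lower number that less compound is needed), where compound 2 gives 73200 nM. Its nearest neighbour is compound 1 `CCCCNc1cc(C)nc(N)n1`, which differs only in bearing a methyl group on an aromatic carbon of the core; in this assay compound 1 gives 22000 nM. Among the measured compounds shown here, the one measured step, a 3.3-fold higher number from compound 1 to compound 2 (0.52 log units; beyond the scatter), shows that taking away that methyl group raises the number by a modest margin.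

Compound 3 `CCCCNc1cc(-c2ccccc2)nc(N)n1` has not yet been measured. It differs from compound 2 by phenyl in place of hydrogen on an aromatic carbon, so a larger carbon group now sits on an aromatic carbon of the core. For the measured compounds named here, only that one step bears on this change, and it points toward a lower number when a carbon group occupies such a position; a larger group may push further, but nothing measured shows by how much. Compound 3 is therefore expected to give 8000 nM in this assay, within a range from 1500 nM to 40000 nM. The expected step is a 9.2-fold lower number from compound 2 to compound 3 (0.96 log units; beyond the scatter).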

Compound 3, half-maximal effective concentration: 6700 nM
The estimate for compound 3 lay 1.2-fold (0.08 log units) above the measured number; low and high end bracket the measured number.
By their numbers in this assay, from the lowest: compound 3; then compound 1; then compound 2.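

In this assay this carbon, next to the ring nitrogen, accepts far more than a small group: phenyl in place of hydrogen gives an 11-fold lower number from compound 2 to compound 3 (1.04 log units; beyond the scatter), a large step beside the modest one seen for methyl. Phenyl also goes beyond methyl at the same place, with a 3.3-fold lower number from compound 1 to compound 3 (0.52 log units; beyond the scatter), so the earlier step was not the limit of what a carbon group can do here. Across these three compounds the number falls in order from hydrogen through methyl to phenyl, and none goes against that order, although no measurement explains the trend.

Three groups at one position cannot show whether the fall follows the number of carbon atoms or needs an aromatic ring, and a cyclohexyl group or a hexyl chain at this carbon would help to tell those two readings apart. From the compounds shown here alone, all three compounds also keep the same butylamino and amino groups, so it remains open whether phenyl would give a similar step alongside a longer chain, such as pentylamino, in place of butylamino.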